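A heteroaryl exchange and its expected effect on potency

The source may report more compounds than this note shows. Statements on the series, on what has been measured and on what is new or still open speak of the compounds shown alone.

Compound 1 `CC(C)(N)CC(=O)N[C@@H]1CCc2ccccc2N(Cc2ccc(-c3ccccc3-c3ncno3)cc2)C1=O`: 30 nM
Compound 2 `CC(C)(N)CC(=O)N[C@@H]1CCc2ccccc2N(Cc2ccc(-c3ccccc3-c3nc[nH]n3)cc2)C1=O`: 90 nM

In a functional assay (Pituitary gland cell) with Rattus norvegicus as the target (a higher number here means that more compound is needed for the effect, a lower number that less compound is needed), compound 2 stands with the higher of the two numbers; compound 1 stands below it, the step being a 3.0-fold higher number from compound 1 to compound 2 (0.48 log units; beyond the scatter). Compound 3 `COc1nsnc1-c1ccccc1-c1ccc(CN2C(=O)[C@H](NC(=O)CC(C)(C)N)CCc3ccccc32)cc1` is not yet measured and differs from compound 2 by a group of 7 heavy atoms (3 carbon, 2 nitrogen, 1 oxygen, 1 sulfur; one five-membered aromatic ring with 3 hetero atoms) in place of a group of 5 heavy atoms (2 carbon, 3 nitrogen; one five-membered aromatic ring with 3 hetero atoms), on an aromatic carbon. Among the compounds with values here, the only measured step that bears on this exchange is a 3.0-fold higher number from compound 1 to compound 2 (0.48 log units; beyond the scatter), a modest change between two five-membered rings. A step of similar size, back toward compound 1, is therefore expected. Compound 3 is expected to give 40 nM, between 10 nM and 160 nM. This estimate means an expected step of a 2.3-fold lower number from compound 2 to compound 3 (0.35 log units; beyond the scatter).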

Compound 3, half-maximal effective concentration: 1800 nM
Compound 3: the middle estimate sits 45-fold (1.65 log units) below what was measured; measured number above the stated range.
By their numbers in this assay, from the lowest: compound 1; then compound 2; then compound 3.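

At this place, on an aromatic carbon ortho to a large group, a five-membered aromatic ring with 3 hetero atoms does not by itself keep the effect in this assay: the larger group with no hydrogen-bond donor gives a 20-fold higher number from compound 2 to compound 3 (1.30 log units; beyond the scatter) and a 60-fold higher number from compound 1 to compound 3 (1.78 log units; beyond the scatter). The place therefore separates these rings far more sharply than the earlier exchange suggested. Nothing available explains this difference. The compounds shown leave open whether the change follows from the ring's sulfur or from its added oxygen and carbon atoms. They also leave open how a tetrazole or a carboxylic acid would behave here.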